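Phenoxy in Place of Methoxyphenyl: Expected Maximal Response

The source may report more compounds than this note shows. Statements on the series, on what has been measured and on what is new or still open speak of the compounds shown alone.

Three compounds have been measured in a functional assay for agonist activity at growth hormone secretagogue receptor type 1 (Homo sapiens), read by FLIPR; on this read-out higher numbers stand for larger maximal responses and lower numbers for smaller maximal responses:

Compound 1 `C[C@@H]1CN(c2cccc(NS(=O)(=O)c3ccc(-c4ccccn4)s3)c2)C[C@H](C)N1` gives 0.8.
Compound 2 `C[C@@H]1CN(c2cc(NS(=O)(=O)c3ccc(-c4ccccn4)s3)ccc2C#N)C[C@H](C)N1` gives 0.9.
Compound 3 `COc1cccc(-c2ccc(S(=O)(=O)Nc3cc(N4C[C@@H](C)N[C@@H](C)C4)ccc3OC)cc2)c1` gives 1.

Compound 3 has the highest number of the three. Its gap to compound 2 lies within the scatter, so the two cannot be told apart, while compound 1 lies beyond the scatter below compound 3. Going by the values given here, the only single-point step among the measured compounds is a number 0.10 higher from compound 1 to compound 2 (within the scatter), and it concerns a different part of the molecule than the change now at hand.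

Compound 4 `COc1ccc(N2C[C@@H](C)N[C@@H](C)C2)cc1NS(=O)(=O)c1ccc(Oc2ccccc2)cc1` differs from compound 3 in one place: phenoxy in place of 3-methoxyphenyl on an aromatic carbon. Among the compounds with values here, no measured step bears on this exchange, so there is nothing in the data to point up or down. The expectation is therefore a number close to that of compound 3, with no step beyond the scatter, the estimated step being a number 0.10 lower from compound 3 to compound 4 (within the scatter). Compound 4 is estimated at 0.9, within a range from 0.7 to 1.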

Compound 4, intrinsic activity: the largest response reached, as a fraction of the reference agonist's: 0.9
For compound 4 middle estimate and measured number coincide at the digits printed, within the range that was stated.
By their numbers in this assay, from the lowest: compounds 1, 2, 4 and 3 (each within the scatter of the next, the first and the last beyond it).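

In this assay, phenoxy in place of 3-methoxyphenyl on this aromatic carbon, para to a large group, gives a number 0.10 lower from compound 3 to compound 4 (within the scatter), so the two compounds cannot be told apart on this read-out. This is the first single-place change shown at this position, and it indicates that the maximal response holds with either group, one of 8 heavy atoms and the other of 7, each carrying one six-membered aromatic ring of carbon only. No supporting measurement explains why the two groups give such similar numbers.

Still open, on these data alone, is whether the maximal response would hold with a group lacking an aromatic ring at this position, such as an amine or a carboxylic acid. As far as these compounds go, it is equally open what a longer chain between the aromatic ring and the shared core would do.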